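The source may hold more compounds than are shown below. What is called first, only, known or untested is meant among the compounds shown, and "the series" means these compounds.

Going by the values given here, in a functional assay on SK-OV-3 cells (Homo sapiens) for antiproliferative activity, read by MTT assay, with a stated time of 72 h (a lower number here means a stronger inhibitor, a higher number a weaker inhibitor), compound 1 `O=C(CCc1cccc2c1B(O)OC2)Nc1ccc(F)cc1` gives 720 nM, while compound 2 `CC(C)(C)c1ccc(NC(=O)CCc2cccc3c2B(O)OC3)cc1` gives 4200 nM, the higher, and so weaker, of the two numbers so far. Compound 3 `CC(C)(C)OC(=O)Nc1ccc(NC(=O)CCc2cccc3c2B(O)OC3)cc1` has (tert-butoxycarbonyl)amino in place of tert-butyl on an aromatic carbon, para to a large group: (tert-butoxycarbonyl)amino in place of tert-butyl on an aromatic carbon. Among the compounds with values here, only one measured step bears on this change. It is a 5.8-fold higher number from compound 1 to compound 2 (0.77 log units; beyond the scatter), a modest step that came with tert-butyl in place of fluoro on an aromatic carbon. Within the data shown here, it shows that a swap of this kind can move the number beyond the scatter, but no measured compound carries the entering group, so the direction is uncertain. The expected change is therefore smaller than that step, leaning slightly towards a lower number and possibly within the scatter, with an estimated 1.4-fold lower number from compound 2 to compound 3 (0.15 log units; within the scatter). For compound 3 the estimated value is 3000 nM, with an expected range of 1000 nM to 9000 nM.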

Compound 3, half-maximal inhibitory concentration: > 100000 nM
Compound 3 gave a limit, no number (the forecaster's own chance of this, stated with the estimate: 10%); middle value at least 33-fold (1.52 log units) away from the limit.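

In this assay compound 3 gives > 100000 nM, which is a limit of the assay and not a number. Even read as a limit, the change to (tert-butoxycarbonyl)amino brings an at least 23-fold higher number from compound 2 to compound 3 (1.37 log units; beyond the scatter), and set against fluoro it brings an at least 130-fold higher number from compound 1 to compound 3 (2.14 log units; beyond the scatter), so both steps are large, whereas the earlier step at this aromatic carbon was modest. Fluoro and tert-butyl in this place both leave a measured number, so the position is far from indifferent to the group it carries, and compound 3 stands alone at the top of the range: the limit of > 100000 nM in this assay, at which 1 of the 3 values shown sits.

The compounds shown do not reveal which part of the entering group matters, a question that a plain amine or an acetamide at the same carbon could address. They also leave open how far past the limit compound 3 lies, and so the true size of both steps.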